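A few compounds are considered here, and "the series" means these few. Any claim that something is new, unique, unknown or untested is made for them only; others in the source may bear on it.

Measured so far, in an assay on HEK293 cells for displacement of a labelled ligand from 5-hydroxytryptamine receptor 6 (Homo sapiens); on this read-out higher numbers stand for weaker inhibition and lower numbers for stronger inhibition:

compound 1, `O=S(=O)(c1cccc(Cl)c1)N1CCOc2c(N3CCNCC3)cccc21`: 2 nM
compound 2, `O=S(=O)(c1cccc(F)c1)N1CCOc2c(N3CCNCC3)cccc21`: 10 nM
compound 3, `O=S(=O)(c1ccccc1F)N1CCOc2c(N3CCNCC3)cc(F)cc21`: 0.631 nM

Compound 1 and compound 2 share a core and differ only in one group: chloro in place of fluoro on an aromatic carbon. That change gave a 5.0-fold lower number from compound 2 to compound 1 (0.70 log units; beyond the scatter).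

Compound 3 has a different core; how it differs from compound 2 is not broken down here. Among the three, compound 3 gives the lowest number, and its steps to compound 1 and compound 2 are both beyond the scatter.

Compound 4, `O=S(=O)(c1ccccc1F)N1CCOc2c(N3CCNCC3)cc(Cl)cc21`, has not been measured yet. It differs from compound 3 in one place: chloro in place of fluoro on an aromatic carbon. For the measured compounds named here, this is the same kind of change as the one from compound 2 to compound 1, but not the same: there the place was an aromatic carbon of a six-membered aromatic ring of carbon only, meta to a large group, whereas here the ring is part of a fused or bridged system of two rings, meta to a fused ring, meta to a piperazin-1-yl group and para to a fused ring.

For compound 4, a step of a 1.6-fold lower number from compound 3 to compound 4 (0.20 log units; within the scatter) in this assay is expected, more cautious than the earlier one because a 5.0-fold lower number from compound 2 to compound 1 (0.70 log units; beyond the scatter) was seen on another ring. Compound 4 is estimated at 0.4 nM, between 0.15 nM and 1.3 nM.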

Compound 4, inhibition constant: 0.398 nM
Compound 4: the middle estimate sits 1.0-fold (0.00 log units) above what was measured; low and high end bracket the measured number.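

On the fused ring, chloro in place of fluoro gave a 1.6-fold lower number from compound 3 to compound 4 (0.20 log units; within the scatter) in this assay, so compound 3 and compound 4 cannot be told apart on this read-out. For the compounds shown here, the size of the step therefore did not carry over from one core to the other: the same change on two cores in this assay, a 5.0-fold lower number (0.70 log units; beyond the scatter) from compound 2 to compound 1 and a 1.6-fold lower number (0.20 log units; within the scatter) from compound 3 to compound 4, 3.2-fold (0.50 log units) apart, beyond the scatter of two such steps This shows that a clear step on one core does not guarantee a clear step on another, but it rests on only two pairs of compounds and does not show why the two steps differ, since the cores and the rings carrying the change are both different.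

The compounds shown leave open how a bromo, methyl or methoxy group would compare with chloro and fluoro at either place. They also leave open which size of step the same change would give on a third core, or with a methyl group on the piperazin-1-yl group.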